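Hydroxymethyl to methyl on compound 1

This account rests on a few compounds, and the source may have more. Where it says the series, first, only, none or still open, it means among the compounds named here.

Within the data shown here, in a physicochemical assay for lipophilicity (a lower number here means a more polar compound, a higher number a more lipophilic compound), compound 1 `C/C1=C\[C@@H]2[C@H](CC[C@@]3(C)O[C@@H]3[C@H]3[C@@H](O)[C@@H](CO)C[C@]3(OC(=O)/C=C/c3ccccc3)C1=O)C2(C)C` gives 4.8 and stands lowest of the two numbers so far, while compound 2 `CC(=O)OC[C@H]1C[C@]2(OC(=O)/C=C/c3ccccc3)C(=O)/C(C)=C/[C@@H]3[C@H](CC[C@@]4(C)O[C@@H]4[C@H]2[C@H]1OC(C)=O)C3(C)C` gives 6.2 as the higher one, beyond the scatter. The change hydrogen in place of hydroxy on a saturated chain carbon bound to a saturated ring carbon puts hydrogen in place of hydroxy on a saturated chain carbon bound to a saturated ring carbon, reading hydroxymethyl to methyl, and turns compound 1 into compound 3 `C/C1=C\[C@@H]2[C@H](CC[C@@]3(C)O[C@@H]3[C@H]3[C@@H](O)[C@@H](C)C[C@]3(OC(=O)/C=C/c3ccccc3)C1=O)C2(C)C` on the same core. Among the measured compounds shown here, no measured pair shows this change alone. The estimated step of a number 0.80 log units higher from compound 1 to compound 3 (beyond the scatter) is expected to be a rise beyond the scatter in this assay for this change. Compound 3 is expected at 5.6 within an estimated range from 5.1 to 6.1 in this read-out.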

Compound 3, partition coefficient: 5.8
Compound 3: the middle estimate sits 0.20 log units below what was measured; the measured number falls inside the stated range.
By their numbers in this assay, from the lowest: compound 1; then compound 3; then compound 2.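

In this assay hydroxymethyl to methyl reads a number 1.00 log units higher from compound 1 to compound 3 (beyond the scatter) on the shared core, giving the series its first pair that differs in one place. This position is therefore shown to respond to the change: hydrogen in place of hydroxy on a saturated chain carbon bound to a saturated ring carbon moves the read-out beyond the scatter. Nothing at hand explains the size of the step.

Still open, from the compounds shown here alone, is how an amine, a carboxylic acid or a longer chain at this place would read in this assay. Also open, going by these compounds, is whether hydroxymethyl to methyl gives a similar step on another core.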